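The source may hold more compounds than are shown below. What is called first, only, known or untested is meant among the compounds shown, and "the series" means these compounds.

Measured compounds:
Compound 1 `C/C=C/C(=O)N(Cc1cc(OC)c(OC)c(OC)c1)c1ccc(OC)c(O)c1` gives 8450 nM in a functional assay on HCT-116 cells (Homo sapiens) for inhibition, read by MTT assay, with a stated time of 48 h; on this read-out lower numbers stand for stronger inhibition and higher numbers for weaker inhibition.
Compound 2 `C#CC(=O)N(Cc1ccc(OC)c(O)c1)c1cc(OC)c(OC)c(OC)c1` gives 310 nM in this assay.

Going by the values given here, of the two numbers so far, compound 2 has the lower one, and its nearest neighbour, compound 1, sits well above it, beyond the scatter of the assay; since the two differ in more than one place, nothing more than this gap can be read from the pair.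

Compound 3 `COc1ccc(CN(C(=O)/C=C/CBr)c2cc(OC)c(OC)c(OC)c2)cc1O` has not yet been measured. It departs from compound 2 at a single spot: 3-bromoprop-1-en-1-yl in place of ethynyl on a carbonyl carbon. The rest of the molecule is unchanged.

Among the compounds with values here, with no measured pair showing exactly this exchange, the expectation rests on compound 2 alone, whose value 310 nM serves as the anchor. The step is expected to be modest and toward a higher number, meaning weaker inhibition, as a 2.6-fold higher number from compound 2 to compound 3 (0.41 log units; beyond the scatter) expresses. Compound 3 is therefore expected to give about 800 nM in this assay, with a plausible range from 200 nM to 3000 nM.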

Compound 3, half-maximal inhibitory concentration: 59 nM
Compound 3: middle estimate off by 14-fold (1.13 log units), on the high side, outside the stated range (below it).
By their numbers in this assay, from the lowest: compound 3; then compound 2; then compound 1.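

Going by these compounds alone, this is the first comparison here that differs in one place only, so it can be read directly: in this assay, putting 3-bromoprop-1-en-1-yl in place of ethynyl on the carbonyl carbon gives a 5.3-fold lower number from compound 2 to compound 3 (0.72 log units; beyond the scatter) and this step lies beyond the scatter. For this pair, then, the triple bond is not needed for inhibition, and a larger group carrying a double bond and a bromine goes with a stronger result. No measurement shown here explains the drop in the number.

On these data alone, compound 3 brings in the bromine, the double bond and the longer chain all at once, so their separate contributions remain open. A chlorine or a dimethylamino group in place of the bromine, or a saturated propyl chain on the carbonyl carbon, would be needed to separate them.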